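Swapping the group on sulfur in compound 3

The source may report more compounds than this note shows. Statements on the series, on what has been measured and on what is new or still open speak of the compounds shown alone.

In a functional assay on DU-145 cells (Homo sapiens) for inhibition, read by trypan blue exclusion, with a stated time of 96 h (on this read-out lower numbers stand for stronger inhibition of growth and higher numbers for weaker inhibition of growth), compound 3 `COc1ccccc1/C=C(/SCc1ccccc1F)C(=O)c1ccc(Cl)cc1` gives 10000 nM, the lower of the two actual numbers available. Compound 2 `Cc1ccc(S/C(=C/c2sccc2C)C(=O)c2ccc(Cl)cc2)cc1` gives 50000 nM, a gap beyond the usual scatter. Compound 1 `Cc1ccc(S/C(=C/c2ccc(N(C)C)cc2)C(=O)c2ccc(Cl)cc2)cc1` reads > 100000 nM, which is a limit of the assay and not a number.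

Compound 4 `COc1ccccc1/C=C(/Sc1ccc(C)cc1)C(=O)c1ccc(Cl)cc1` differs from compound 3 in one place: 4-methylphenyl in place of 2-fluorobenzyl on a sulfur, with 4-methylphenyl in place of 2-fluorobenzyl on a sulfur. Among the measured compounds shown here, no measured step makes this swap. The only one available, an at least 2.0-fold lower number from compound 1 to compound 2 (0.30 log units; that floor lies within the scatter), changes a different group, so it bears on this question only indirectly. Compound 2 already carries 4-methylphenyl on sulfur and gives 50000 nM, so a moderate move towards weaker inhibition of growth is expected, although that comparison also involves a different group elsewhere.

The estimated change is a 3.0-fold higher number from compound 3 to compound 4 (0.48 log units; beyond the scatter), a rough expectation from very few compounds. For compound 4, the expected value in this assay is 30000 nM, with an estimated range from 8000 nM to 100000 nM.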

Compound 4, concentration for 50% growth inhibition: 25000 nM
Compound 4: the middle estimate sits 1.2-fold (0.08 log units) above what was measured, and the stated range covers the measured number.
By their numbers in this assay, from the lowest: compound 3; then compounds 4 and 2 (each within the scatter of the next). At a limit, above all of these: compound 1.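

In this assay, the group on sulfur now has a measured step of its own: with 2-methoxyphenyl held constant, 4-methylphenyl in place of 2-fluorobenzyl gives a 2.5-fold higher number from compound 3 to compound 4 (0.40 log units; beyond the scatter), a modest move towards weaker inhibition of growth. With 4-methylphenyl held on sulfur, 2-methoxyphenyl in place of 3-methylthiophen-2-yl gives a 2.0-fold lower number from compound 2 to compound 4 (0.30 log units; within the scatter), so these two compounds cannot be told apart. 2-Methoxyphenyl in place of 4-(dimethylamino)phenyl gives an at least 4.0-fold lower number from compound 1 to compound 4 (0.60 log units; beyond the scatter), and this size is only a floor because compound 1 stands at a limit and not at a number: the limit of > 100000 nM in this assay, at which 1 of the 4 values shown sits.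

On these data alone, it remains open whether the step on sulfur follows the fluorine or the carbon link of the benzyl group, which a plain benzyl group would help to separate. As far as these compounds go, how an amine or a carboxylic acid on the sulfur substituent would read is also open.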